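This account rests on a few compounds, and the source may have more. Where it says the series, first, only, none or still open, it means among the compounds named here.

Measured in an ADME assay on Vero cells (Chlorocebus sabaeus) for antiproliferative activity, read by MTT assay, with a stated time of 72 h; on this read-out higher numbers stand for weaker inhibition and lower numbers for stronger inhibition:
- compound 1 `Cc1cccc(N(C)S(=O)(=O)C2CC3OC2C(c2ccc(NC(=O)CCCCCCC(=O)O)cc2)=C3c2ccc(O)cc2)c1`: > 100000 nM
- compound 2 `CCN(c1ccccc1)S(=O)(=O)C1CC2OC1C(c1ccc(NC(=O)CCCCCCC(=O)O)cc1)=C2c1ccc(O)cc1`: > 100000 nM

Both entries are limits of the assay and not numbers. Compound 2 has only the limit > 100000 nM, so its position in the series cannot be fixed more closely. The overall picture in this assay is the limit of > 100000 nM in this assay, at which 2 of the 2 values shown sit.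

The next compound, compound 3 `CCN(c1ccc(O)cc1)S(=O)(=O)C1CC2OC1C(c1ccc(NC(=O)CCCCCCC(=O)O)cc1)=C2c1ccc(O)cc1`, differs from compound 2 by one change: hydroxy in place of hydrogen on an aromatic carbon. In words, hydroxy replaces hydrogen on an aromatic carbon, turning ethyl(phenyl)amino into ethyl(4-hydroxyphenyl)amino.

For the measured compounds named here, the only measured step that bears on this change is a step that the two limits leave unreadable from compound 1 to compound 2. It involves a different part of the substituent on the sulfonyl sulfur and gives no size to carry over. With both measured compounds at the limit, no step beyond the scatter is expected in this assay, in either direction, and a further limit is the likeliest report.

The estimated step is a number no higher from compound 2 to compound 3 (the limit leaves the size open). The expected value for compound 3 is 100000 nM. The estimated range for compound 3 runs from 40000 nM to 150000 nM.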

Compound 3, half-maximal inhibitory concentration: > 100000 nM
Compound 3: no number, only a limit; the forecaster's own chance of this, stated with the estimate: 75%; the middle value lies on the limit itself.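

In this assay compound 3 gives > 100000 nM, a limit of the assay and not a number. No step can be read from compound 2 to compound 3 or from compound 1 to compound 3. The compounds shown leave open where the half-maximal inhibitory concentration of any of the three lies, and so what hydroxy in place of hydrogen does in this assay.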